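A Second Chloro on the Aryl Ring of Compound 1

This account rests on a few compounds, and the source may have more. Where it says the series, first, only, none or still open, it means among the compounds named here.

For the measured compounds named here, compound 1 `CC(C)C(NC(=O)c1ccccc1)C(=O)N1CCN(c2ccc(Cl)cc2)CC1` was tested in an assay on THP-1 cells for displacement of a labelled ligand from C-C chemokine receptor type 1 (Homo sapiens) (on this read-out lower numbers stand for stronger inhibition and higher numbers for weaker inhibition), where compound 1 gives 525 nM, the highest of the two numbers measured so far. Going by the values given here, the only other measured compound, compound 2 `CC(C)[C@@H](NC(=O)c1cc2ccccc2s1)C(=O)N1CCC(c2ccc(Cl)cc2)CC1`, gives 58 nM in this assay, a lower number beyond the usual scatter; the two structures differ in several places at once, so no single step can be read from them. Compound 3 `CC(C)C(NC(=O)c1ccccc1)C(=O)N1CCN(c2ccc(Cl)c(Cl)c2)CC1` has not yet been measured. It differs from compound 1 by chloro in place of hydrogen on an aromatic carbon, so that the 4-chlorophenyl group becomes a 3,4-dichlorophenyl group. Among the compounds with values here, no measured pair shows this change, and its effect here is unknown. Compound 3 is expected to give a somewhat lower number, with the step from compound 1 to compound 3 estimated at a 1.8-fold lower number from compound 1 to compound 3 (0.24 log units; within the scatter). The estimated value of compound 3 in this assay is 300 nM, within a range from 100 nM to 900 nM.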

Compound 3, half-maximal inhibitory concentration: 375 nM
Compound 3: middle estimate off by 1.3-fold (0.10 log units), on the low side; low and high end bracket the measured number.
By their numbers in this assay, from the lowest: compound 2; then compounds 3 and 1 (each within the scatter of the next).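

In this assay, the first step readable at this position is a 1.4-fold lower number from compound 1 to compound 3 (0.15 log units; within the scatter), so the change from 4-chlorophenyl to 3,4-dichlorophenyl cannot be told apart from repeat measurement. A chloro group on this aromatic carbon, ortho to the existing chloro group, is therefore tolerated on the core of compound 1, something the earlier pair, differing in several places at once, could not show. Nothing measured here bears on the reason for this result. From the compounds shown here alone, whether a methoxy group, a trifluoromethyl group or an amine on this same carbon would also leave the number within the scatter remains open. Also open, going by these compounds, is whether chloro in place of hydrogen here would give a similar step on the core of compound 2.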